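A few compounds are considered here, and "the series" means these few. Any claim that something is new, unique, unknown or untested is made for them only; others in the source may bear on it.

Three measured members of the series share one core and differ only in the aryl on the nitrogen. Compound 1 `COc1ccc(Nc2nc3ccccc3nc2S(=O)(=O)c2ccc(OC)cc2)cc1` gives 8710 nM in a functional assay on PC-3 cells (Homo sapiens) for cytotoxicity, read by MTT assay, with a stated time of 72 h; on this read-out lower numbers stand for stronger inhibition and higher numbers for weaker inhibition. Compound 2 `COc1ccc(S(=O)(=O)c2nc3ccccc3nc2Nc2cc(OC)cc(OC)c2)cc1` gives 6220 nM in this assay. Compound 3 `COc1ccc(S(=O)(=O)c2nc3ccccc3nc2Nc2ccc(F)cc2)cc1` gives 2200 nM in this assay. Compound 2 therefore stands second highest of the three numbers: a 1.4-fold lower number from compound 1 to compound 2 (0.15 log units; within the scatter) lies within the scatter, while a 2.8-fold lower number from compound 2 to compound 3 (0.45 log units; beyond the scatter) lies beyond it, and a 4.0-fold lower number from compound 1 to compound 3 (0.60 log units; beyond the scatter) is the largest step seen.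

Compound 4 `COc1cc(Nc2nc3ccccc3nc2S(=O)(=O)c2ccc(Br)cc2)cc(OC)c1` keeps the 3,5-dimethoxyphenyl of compound 2 and alters the other ring instead: bromo in place of methoxy on an aromatic carbon. Going by the values given here, none of the measured steps bears directly on this position, since all three change the aryl on the nitrogen. Among the compounds with values here, the only single-substituent swap recorded, a 4.0-fold lower number from compound 1 to compound 3 (0.60 log units; beyond the scatter), was modest and sits on the other ring. No step beyond the scatter is therefore expected here. Compound 4 is estimated at 5500 nM in this assay, with a range from 2000 nM to 15000 nM. This estimate corresponds to an expected step of a 1.1-fold lower number from compound 2 to compound 4 (0.05 log units; within the scatter).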

Compound 4, half-maximal inhibitory concentration: 18200 nM
Compound 4: the middle estimate sits 3.3-fold (0.52 log units) below what was measured; measured number outside the range, above it.
By their numbers in this assay, from the lowest: compound 3; then compounds 2 and 1 (each within the scatter of the next); then compound 4.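

The position carrying the 4-methoxyphenyl is not silent in this assay: 4-bromophenyl in its place gives a 2.9-fold higher number from compound 2 to compound 4 (0.47 log units; beyond the scatter) and so moves the number upward. Going by these compounds alone, this is the first measured change on this ring, and its direction is opposite to that of the one halogen-for-methoxy swap on the aryl on the nitrogen (a 4.0-fold lower number from compound 1 to compound 3 (0.60 log units; beyond the scatter)), so a swap of this kind does not read the same on both rings, although the halogens also differ. No measurement shown bears on why the number rises here.

Going by these compounds, whether the rise follows from the bromo itself or from the loss of the methoxy stays open, as does whether it holds with another aryl on the nitrogen. A fluoro, a hydroxy, an amine or a carboxylic acid at this place would help to separate these readings.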